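The source may report more compounds than this note shows. Statements on the series, on what has been measured and on what is new or still open speak of the compounds shown alone.

Compound 1 `N/C(=N\NC(=S)N1CCN(c2ccccn2)CC1)c1ccc(F)cn1` gives 47.4% in a functional assay on A-431 cells (Homo sapiens) for cytotoxicity, read by MTT assay, with a stated time of 72 h, tested at 10 uM; a higher number here means more inhibition of growth at the concentration tested, a lower number less inhibition of growth; compound 2 `N/C(=N\NC(=S)N1CCCC1)c1ccc(F)cn1` gives 78.7%; compound 3 `N/C(=N\NC(=S)N1CCOCC1)c1ccc(F)cn1` gives 66.9%.

Compound 2 stands highest of the three in this assay: the step of a number 11.8 percentage points lower from compound 2 to compound 3 (beyond the scatter) is beyond the scatter, and compound 1 lies further below still. Compound 4 `N/C(=N\NC(=S)N1CCCC1)c1ccccn1` differs from compound 2 in one place, (hydrogen in place of fluoro on an aromatic carbon). For the measured compounds named here, none of the measured steps bears on this position: the only measured step, a number 11.8 percentage points lower from compound 2 to compound 3 (beyond the scatter), and the gap between compound 2 and compound 1 both concern the group on the thiocarbonyl carbon, not the ring bearing the fluoro. Nothing here therefore points to a change beyond the scatter, and the expected step is a number 6.7 percentage points lower from compound 2 to compound 4 (within the scatter). Compound 4 is estimated at 72%, with a range from 50% to 90%.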

Compound 4, percent growth inhibition at one concentration: 77.2%
The estimate for compound 4 lay 5.2 percentage points below the measured number; the measured number falls inside the stated range.
By their numbers in this assay, from the lowest: compound 1; then compound 3; then compounds 4 and 2 (each within the scatter of the next).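

In this assay, for the compounds shown here, the change of fluoro to hydrogen on the aromatic carbon gives a number 1.5 percentage points lower from compound 2 to compound 4 (within the scatter), the first measured step at this position. With pyrrolidin-1-yl on the thiocarbonyl carbon, therefore, the fluoro is not needed to keep growth inhibition within the scatter at this single concentration. The data offer no measured explanation for this result.

The compounds shown leave open how an amine, a methoxy group or a carboxylic acid would read at this position. They also leave open whether removing the fluoro gives the same result with morpholin-4-yl on the thiocarbonyl carbon.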